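Trifluoromethyl gives way to (4-methoxyphenyl)amino

This account rests on a few compounds, and the source may have more. Where it says the series, first, only, none or still open, it means among the compounds named here.

In a functional assay on K562 cells (Homo sapiens) for antiproliferative activity, read by MTT assay (a higher number here means a weaker inhibitor, a lower number a stronger inhibitor), compound 1 (`O=C1NC(c2ccccc2)CN1S(=O)(=O)c1ccc2c(c1)CCCN2C(=O)C(F)(F)F`) gives > 20000 nM as a limit of the assay. Compound 2 (`CC1(c2ccccc2)CN(S(=O)(=O)c2ccc3c(c2)CCCN3C(=O)C(F)(F)F)C(=O)N1`) gives > 20000 nM as a limit too. Compound 3 (`COc1ccc(NC(=O)N2CCCc3cc(S(=O)(=O)N4CC(C)(c5ccccc5)NC4=O)ccc32)cc1`) differs from compound 2 by (4-methoxyphenyl)amino in place of trifluoromethyl on a carbonyl carbon with (4-methoxyphenyl)amino in place of trifluoromethyl on a carbonyl carbon. For the measured compounds named here, the only measured step is a step that the two limits leave unreadable from compound 1 to compound 2 and it offers no size to carry over. Going by the values given here, with the limit of > 20000 nM in this assay, at which 2 of the 2 values shown sit, as the sole guide, any readable step can only point toward stronger inhibition, by an uncertain amount. The expected step is an at least 6.6-fold lower number from compound 2 to compound 3 (0.82 log units; beyond the scatter) as a rough estimate. Compound 3 is expected at 3000 nM within an estimated range of 300 nM to 20000 nM as a wide guess.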

Compound 3, half-maximal inhibitory concentration: 12400 nM
Beside the measured number, compound 3's estimate is 4.1-fold (0.62 log units) below it, within the range that was stated.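

In this assay, (4-methoxyphenyl)amino in place of trifluoromethyl on this carbonyl carbon gives an at least 1.6-fold lower number from compound 2 to compound 3 (0.20 log units; that floor lies within the scatter), so this position can carry a larger group and still yield a readable number. For the compounds shown here, that size is only a floor, and compound 3 is the first compound here with a number rather than a limit. The step from compound 1 to compound 2 cannot be read, because both compounds sit at a limit: the limit of > 20000 nM in this assay, at which 2 of the 3 values shown sit.

Still open, from the compounds shown here alone, is how a plain phenylamino group or a morpholine on this carbonyl carbon would compare with (4-methoxyphenyl)amino.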